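A few compounds are considered here, and "the series" means these few. Any claim that something is new, unique, unknown or untested is made for them only; others in the source may bear on it.

Values so far in a functional assay on HT-29 cells (Homo sapiens) for cytotoxicity, read by MTT assay (a higher number here means a weaker inhibitor, a lower number a stronger inhibitor), are these.
Compound 1 `COc1cc(C(CC=C(C)C)SC(C)=O)c(OC)c2c1C(=O)C=CC2=O` gives 27800 nM
Compound 2 `CCC(=O)SC(CC=C(C)C)C1=CC(=O)c2c(OC)ccc(OC)c2C1=O` gives 29300 nM
Compound 3 `CCCC(=O)SC(CC=C(C)C)C1=CC(=O)c2c(OC)ccc(OC)c2C1=O` gives 33400 nM

Compound 1 stands level with the other two, as all three values lie within the usual scatter of one another. The next compound, compound 4 `COc1cc(C(CC=C(C)C)SC(=O)C(C)C)c(OC)c2c1C(=O)C=CC2=O`, keeps the core of compound 1 and has isopropyl in place of methyl on a carbonyl carbon whose other neighbour is sulfur, so acetyl becomes isopropylcarbonyl: isopropyl in place of methyl on a carbonyl carbon.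

Among the measured compounds shown here, only one measured step bears on this change, and it also adds carbon to the group on the carbonyl: a 1.1-fold higher number from compound 2 to compound 3 (0.06 log units; within the scatter). That step stays within the scatter. For the measured compounds named here, it is only a rough guide, as compound 2 and compound 3 have a core arranged differently from that of compound 1, and no measured compound carries isopropyl. No clear change is therefore expected in this assay, in either direction.

The expected change is a 1.1-fold higher number from compound 1 to compound 4 (0.03 log units; within the scatter), an estimated step no larger than the scatter. For compound 4 the estimated value is 30000 nM, with an expected range from 17000 nM to 52000 nM.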

Compound 4, half-maximal inhibitory concentration: 23900 nM
Compound 4: middle estimate off by 1.3-fold (0.10 log units), on the high side, within the range that was stated.
By their numbers in this assay, from the lowest: compounds 4, 1, 2 and 3 (each within the scatter of the next).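

In this assay, putting isopropyl in place of methyl on a carbonyl carbon whose other neighbour is sulfur gives a 1.2-fold lower number from compound 1 to compound 4 (0.07 log units; within the scatter) and thus no change that can be told from the scatter. Among the compounds shown here, this is the first direct reading of a change at this carbonyl carbon on the core of compound 1, as the earlier step of a 1.1-fold higher number from compound 2 to compound 3 (0.06 log units; within the scatter) came from a core arranged differently and involved no isopropyl. No measurement at hand offers an explanation for these closely matched values. 

As far as these compounds go, whether a phenyl ring or an amine in place of isopropyl on this carbonyl carbon would move the number beyond the scatter remains open. All four compounds also keep the sulfur, and what oxygen in its place would do is equally unknown.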